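Amino Added to Compound 1: Expected Cell Tolerance

The compounds below may be only part of what the source reports. "The series", "measured", "known", "first", "only" and "open" are said of these compounds alone.

Compound 1 `COc1ccc2c(c1)nc1n2[C@H]2OC[C@@H](O)[C@H]2OC1` was tested in an ADME assay on HEp-2 cells (Homo sapiens) for cytotoxicity, read by MTT assay, with a stated time of 60 h; a lower number here means that less compound is tolerated, a higher number that more compound is tolerated. Compound 1 gave > 800000 nM, which is a limit of the assay and not a number; this is the limit of > 800000 nM in this assay, at which 1 of the 3 values shown sits. Two other compounds give numbers in this assay: compound 2 `Cc1c(Br)cc2nc3n(c2c1Br)[C@H]1OC[C@@H](OCc2ccccc2)[C@H]1OC3` gives 115000 nM, and compound 3 `Cc1cc2nc3n(c2cc1C)[C@H]1OC[C@@H](O)[C@H]1OC3` gives 492000 nM.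

Compound 4 `COc1ccc2c(nc3n2[C@H]2OC[C@@H](O)[C@H]2OC3)c1N` differs from compound 1 by amino in place of hydrogen on an aromatic carbon. Among the compounds with values here, no measured pair shows this change, so there is nothing to copy from. The step is expected to be small, a modest drop in tolerated concentration at most, close to the scatter: an at least 1.6-fold lower number from compound 1 to compound 4 (0.20 log units; that floor lies within the scatter). Compound 4 is therefore expected to give about 500000 nM in this assay, with a likely range from 150000 nM to 900000 nM.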

Compound 4, half-maximal cytotoxic concentration: 109000 nM
For compound 4 the middle estimate is 4.6-fold (0.66 log units) above the measured one, and the stated range ends above it.
By their numbers in this assay, from the lowest: compounds 4 and 2 (each within the scatter of the next); then compound 3. At a limit, above all of these: compound 1.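

In this assay, amino in place of hydrogen on an aromatic carbon, ortho to a methoxy group, gives a clear change: an at least 7.3-fold lower number from compound 1 to compound 4 (0.86 log units; beyond the scatter). Within the data shown here, no earlier pair could show that this position of the shared core responds to so small an addition. The real step may be larger, because compound 1 stands at a limit of the assay: the limit of > 800000 nM in this assay, at which 1 of the 4 values shown sits.

Going by these compounds, whether this shift belongs to amino itself or would follow any group at this position, such as a hydroxyl or a dimethylamino group, stays open. So does the effect of amino elsewhere on this ring.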